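Cyanopyridine in place of phenyl on the piperazine nitrogen

This account rests on a few compounds, and the source may have more. Where it says the series, first, only, none or still open, it means among the compounds named here.

Of the compounds shown here, three have been measured in a functional assay on HEK293 cells with D(4) dopamine receptor (Homo sapiens) as the target, read by FLIPR; a lower number here means that less compound is needed, a higher number that more compound is needed for the effect. Compound 1 `Cc1ccccc1/C(CCN1CCN(c2ccccn2)CC1)=N\O` gives 20.3 nM in this assay. Compound 2 `Cc1ccc(OCc2ccccc2)c(/C(CCN2CCN(c3ccccn3)CC2)=N/O)c1` reaches only the limit of this assay, > 10000 nM. Compound 3 `CCO/N=C(\CCN1CCN(c2ccccc2)CC1)c1ccccc1` gives 109 nM in this assay. Going by the values given here, of the two values that are numbers, compound 3 holds the higher one, and its nearest neighbour is compound 1, whose number lies lower by a margin beyond the usual scatter; since the two compounds differ in more than one place, no single step between them can be drawn, and only the two values themselves may be set side by side.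

Compound 4 `CCO/N=C(\CCN1CCN(c2ncccc2C#N)CC1)c1ccccc1` has not yet been measured. It differs from compound 3 in one place: 3-cyanopyridin-2-yl in place of phenyl on an amine nitrogen in a ring. Among the compounds with values here, no measured pair shows this change on its own. The expectation for compound 4 leans on compound 1, which also carries an aromatic ring containing nitrogen on that amine nitrogen in a ring and which gives 20.3 nM, although compound 1 differs from compound 3 elsewhere too. Compound 4 is therefore expected to give 45 nM, in a range from 12 nM to 200 nM. The step of a 2.4-fold lower number from compound 3 to compound 4 (0.38 log units; beyond the scatter) is estimated to be a lowering of moderate size, beyond the scatter, but held with limited confidence.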

Compound 4, half-maximal effective concentration: 139 nM
Beside the measured number, compound 4's estimate is 3.1-fold (0.49 log units) below it; the measured number falls inside the stated range.
By their numbers in this assay, from the lowest: compound 1; then compounds 3 and 4 (each within the scatter of the next). At a limit, above all of these: compound 2.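

Going by these compounds alone, in terms of this assay, putting 3-cyanopyridin-2-yl in place of phenyl on the amine nitrogen in a ring amounts to a 1.3-fold higher number from compound 3 to compound 4 (0.11 log units; within the scatter) and gives the first reading of a change made at this position alone. Within the data shown here, the entering group brings a nitrile, a ring nitrogen and hydrogen-bond acceptors that phenyl lacks, yet compound 3 and compound 4 read alike, something the earlier compounds, which differ from one another in more than one place, could not show. Nothing among the data shown accounts for this outcome.

The step changes the ring nitrogen and the nitrile together, so it leaves open how each would read alone and whether a pyrimidin-2-yl ring or a primary amide in place of the nitrile would also read alike at this position. It also leaves open whether the same exchange would read the same way on the core of compound 1, which carries a different group on the other side of the chain and a ring without the nitrile.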